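Sulfonamide aryl swap carried across two cores

The source may report more compounds than this note shows. Statements on the series, on what has been measured and on what is new or still open speak of the compounds shown alone.

Three compounds share a sulfonamide whose nitrogen bears either a 1,3-thiazol-2-yl or a pyridin-2-yl group. Compound 1 `Nc1ncnc2c1c(-c1ccccc1)cn2-c1ccc(S(=O)(=O)Nc2nccs2)cc1` carries the thiazole; in a functional assay on HepG2 cells (Homo sapiens) for inhibition, read by sulforhodamine B assay, with a stated time of 24 h (a lower number here means a stronger inhibitor, a higher number a weaker inhibitor), compound 1 gives 4240 nM. Compound 2 `Nc1ncnc2c1c(-c1ccccc1)cn2-c1ccc(S(=O)(=O)Nc2ccccn2)cc1` is its pyridine counterpart, with pyridin-2-yl in place of 1,3-thiazol-2-yl on a sulfonamide nitrogen, and in this assay compound 2 gives 4090 nM. The step of a 1.0-fold lower number from compound 1 to compound 2 (0.02 log units; within the scatter) is flat. Compound 3 `Nc1nc(=O)[nH]c2c1c(-c1ccccc1)cn2-c1ccc(S(=O)(=O)Nc2nccs2)cc1` carries the thiazole sulfonamide on a different core; the difference between the core of compound 3 and the core of compound 1 is not broken down here. In this assay compound 3 gives 3490 nM, the lowest of the three numbers, though its gaps to compound 1 and compound 2 both sit within the scatter, so no ordering among the three is claimed.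

Compound 4 `Nc1nc(=O)[nH]c2c1c(-c1ccccc1)cn2-c1ccc(S(=O)(=O)Nc2ccccn2)cc1` has not been measured. It relates to compound 3 as compound 2 relates to compound 1: pyridin-2-yl in place of 1,3-thiazol-2-yl on a sulfonamide nitrogen, at a sulfonamide nitrogen whose other neighbour is sulfonyl sulfur, so this is the same change already seen once. Among the measured compounds shown here, only one prior instance exists, and the expectation rests on it alone. The estimated step of a 1.0-fold lower number from compound 3 to compound 4 (0.01 log units; within the scatter) is expected to be flat, because a 1.0-fold lower number from compound 1 to compound 2 (0.02 log units; within the scatter) showed no movement. In this assay compound 4 is therefore estimated at 3400 nM, expected to fall between 1700 nM and 7000 nM.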

Compound 4, half-maximal inhibitory concentration: 4300 nM
The estimate for compound 4 lay 1.3-fold (0.10 log units) below the measured number; low and high end bracket the measured number.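

In this assay, the swap of 1,3-thiazol-2-yl for pyridin-2-yl on the sulfonamide nitrogen, now read on the second core, gives a 1.2-fold higher number from compound 3 to compound 4 (0.09 log units; within the scatter), so this step is flat, as it was on the core of compound 1. Set side by side, the two steps do not differ, and the change carries from one core to the other without a detectable shift in this cell read-out: the same change on two cores in this assay, a 1.0-fold lower number (0.02 log units; within the scatter) from compound 1 to compound 2 and a 1.2-fold higher number (0.09 log units; within the scatter) from compound 3 to compound 4, 1.3-fold (0.11 log units) apart, within the scatter of two such steps. This rests on two instances only, both flat, so it shows that the two groups can be exchanged on these two cores in this one assay, but it does not show that the same would hold on a further core or in another assay, and a flat step gives no measure of what either group contributes.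

Still open, on these data alone, is whether any group on the sulfonamide nitrogen moves the number at all, for example a plain methyl, a pyrimidin-2-yl ring or a short chain ending in an amine. As far as these compounds go, the phenyl group shared by all four compounds is also unvaried, so the effect of a carboxylic acid or a small alkyl group at that place remains unknown.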